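Moving from 4-fluorophenyl to 3-fluorophenyl on a shared core

A few compounds are considered here, and "the series" means these few. Any claim that something is new, unique, unknown or untested is made for them only; others in the source may bear on it.

Compound 1 `COc1c(OCCCCN2CCN(C)CC2)cc(O)c2c(=O)cc(-c3ccc(C)cc3)oc12`: 4020 nM
Compound 2 `COc1c(OCCCCN2CCN(C)CC2)cc(O)c2c(=O)cc(-c3ccc(F)cc3)oc12`: 3860 nM

Both compounds were tested in a functional assay on MCF7 cells (Homo sapiens) for cytotoxicity, read by MTT assay, with a stated time of 72 h; a lower number here means a stronger inhibitor, a higher number a weaker inhibitor. Among the compounds with values here, there, compound 2 gives 3860 nM, level with compound 1 at 4020 nM, the only other measured value. Compound 3 `COc1c(OCCCCN2CCN(C)CC2)cc(O)c2c(=O)cc(-c3cccc(F)c3)oc12` has not yet been measured. It holds the same atoms as compound 2, joined differently: 3-fluorophenyl in place of 4-fluorophenyl on an aromatic carbon. The group stays on an aromatic carbon next to the ring oxygen of the shared core.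

Within the data shown here, only one measured step bears on this change, with fluoro in place of methyl on an aromatic carbon: a 1.0-fold lower number from compound 1 to compound 2 (0.02 log units; within the scatter). Among the measured compounds shown here, no measured compound carries the 3-fluorophenyl group, so the data offer no direct guide. Given that single small step, no change beyond the scatter is expected in this assay, in either direction. The expected step is a 1.0-fold lower number from compound 2 to compound 3 (0.01 log units; within the scatter). For compound 3 the estimated value is 3800 nM, with an expected range from 1900 nM to 7500 nM.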

Compound 3, half-maximal inhibitory concentration: 2890 nM
Estimate against measurement, compound 3: 1.3-fold (0.12 log units) above; the measured number falls inside the stated range.
By their numbers in this assay, from the lowest: compounds 3, 2 and 1 (each within the scatter of the next).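

In this assay, shifting the fluorine from 4-fluorophenyl to 3-fluorophenyl gives a 1.3-fold lower number from compound 2 to compound 3 (0.13 log units; within the scatter), so this first change of fluorine placement on the phenyl ring, on the aromatic carbon next to the ring oxygen, stays within the scatter. The comparison with the 4-methylphenyl group reads a 1.4-fold lower number from compound 1 to compound 3 (0.14 log units; within the scatter), which is also within the scatter, so all three phenyl groups shown sit level in this assay. Nothing measured here gives a cause for this flat reading.

The compounds shown carry only a fluoro or a methyl group on this phenyl ring, so they leave open whether an amine or a carboxylic acid there would move the number beyond the scatter. They also leave open whether a plain phenyl group would stay level with these three.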